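Phenyl in Place of Thiophen-3-yl: One Step Forward

The source may report more compounds than this note shows. Statements on the series, on what has been measured and on what is new or still open speak of the compounds shown alone.

Measured in a functional assay on HCT-15 cells (Homo sapiens) for cytotoxicity, read by CCK-8 assay and cell counting, with a stated time of 2 days; on this read-out lower numbers stand for stronger inhibition and higher numbers for weaker inhibition:
Compound 1, `Oc1ccc(-c2cc(-c3ccc(Cl)cc3)nc(-c3ccsc3)c2)cc1`: 6240 nM
Compound 2, `Oc1cccc(-c2cc(-c3ccc(Cl)cc3)nc(-c3ccsc3)c2)c1`: 8850 nM

Among the measured compounds shown here, compound 2 holds the higher of the two numbers so far, yet its neighbour compound 1 sits close: the change a 1.4-fold higher number from compound 1 to compound 2 (0.15 log units; within the scatter) lies inside the scatter, so the two are not told apart. Compound 3, `Oc1cccc(-c2cc(-c3ccccc3)nc(-c3ccc(Cl)cc3)c2)c1`, is not yet measured. It differs from compound 2 in one place: phenyl in place of thiophen-3-yl on an aromatic carbon. For the measured compounds named here, no measured step touches this change; the only step available, from compound 1 to compound 2, swaps the position of the hydroxy group on another ring and says nothing about the thiophen-3-yl. With nothing to lean on, the expectation for compound 3 in this assay is a step of a 1.1-fold lower number from compound 2 to compound 3 (0.04 log units; within the scatter), that is, none beyond the scatter, carrying wide uncertainty. The estimated number for compound 3 is 8000 nM, within a range from 2500 nM to 25000 nM.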

Compound 3, half-maximal inhibitory concentration: 8110 nM
For compound 3 the middle estimate is 1.0-fold (0.01 log units) below the measured one, and the stated range covers the measured number.
By their numbers in this assay, from the lowest: compounds 1, 3 and 2 (each within the scatter of the next).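

In this assay, among the compounds shown here, the change of thiophen-3-yl to phenyl gives a 1.1-fold lower number from compound 2 to compound 3 (0.04 log units; within the scatter), the first reading at this aromatic carbon next to the ring nitrogen, since the earlier pair differed only in where the hydroxy group sat. A five-membered aromatic ring with a sulfur atom and a six-membered aromatic ring of carbon only are not told apart at this place, at least with the 3-hydroxyphenyl group in the molecule. No measured evidence bears on why the two groups read alike.

On these data alone, whether this place tolerates anything other than an aromatic ring stays open, for instance a morpholine, a carboxylic acid or a short alkyl chain. Also open, as far as these compounds go, is whether phenyl and thiophen-3-yl would still read alike alongside the 4-hydroxyphenyl group of compound 1.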